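The source may hold more compounds than are shown below. What is called first, only, known or untested is meant among the compounds shown, and "the series" means these compounds.

Compound 1 `O=C1Nc2ccc([N+](=O)[O-])cc2/C1=C\c1ccccn1` was examined in an ADME assay on A549 cells (Homo sapiens) for cytotoxicity, read by MTT assay, with a stated time of 72 h (on this read-out lower numbers stand for stronger inhibition and higher numbers for weaker inhibition), and recorded as "not toxic" (no number reported), without any number being given. Two further compounds were examined as well. Compound 2 `COC(=O)Nc1ccc2c(c1)C(=Cc1ccc([N+](=O)[O-])cc1)C(=O)N2` reached only the limit of > 100000 nM in this assay. Compound 3 `COC(=O)Nc1ccc2c(c1)/C(=C/c1ccc(Br)cc1)C(=O)N2` likewise sat at the limit of > 100000 nM. Compound 1 therefore stands without a single number of its own, alongside (the limit of > 100000 nM in this assay, at which 2 of the 3 values shown sit). Compound 4 `O=C1Nc2ccc(Br)cc2/C1=C\c1ccccn1` has not yet been measured. It differs from compound 1 in one place: bromo in place of nitro on an aromatic carbon. Among the measured compounds shown here, no step between measured compounds is known, so the change expected in this assay is none beyond the usual scatter. Compound 4 is expected to give 100000 nM, in a range from 30000 nM to 300000 nM, most likely reported as a limit rather than a number.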

Compound 4, half-maximal inhibitory concentration: 90600 nM
Beside the measured number, compound 4's estimate is 1.1-fold (0.04 log units) above it; measured number inside the range.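

Among the compounds shown here, compound 1 carries only the entry "not toxic" (no number reported) in this assay, so no step to compound 4 can be read. The compounds shown leave open whether bromo in place of nitro changes this read-out at all.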